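The compounds below may be only part of what the source reports. "The series", "measured", "known", "first", "only" and "open" are said of these compounds alone.

Compound 1 `Cc1c(C(=O)Nc2c(F)cc(-c3cccc(F)c3)cc2F)nc2ccc(C(F)(F)F)cc2c1O`: 0.06%
Compound 2 `CCOc1ccc2nc(C(=O)Nc3c(F)cc(-c4cccc(F)c4)cc3F)c(C)c(C(=O)O)c2c1`: 0.05%

In a functional assay on Hep 3B2 cells (Homo sapiens) for antiproliferative activity, read by MTT assay, with a stated time of 24 h, tested at 0.02 ug/mL (a higher number here means a stronger effect of the compound at the concentration tested, a lower number a weaker effect), compound 1 gives 0.06% and compound 2 gives 0.05%. Compound 2 stands level with compound 1: the gap between them lies within the scatter, so neither is set apart. Compound 3 `Cc1c(C(=O)Nc2c(F)cc(-c3cccc(F)c3)cc2F)nc2ccc(C(F)(F)F)cc2c1C(=O)O` differs from compound 2 by trifluoromethyl in place of ethoxy on an aromatic carbon. Within the data shown here, no measured pair shows this change, so its effect cannot be read from the data; with both measured values near zero, no step beyond the scatter is expected in this assay. For compound 3 the estimate is 0.5%, between 0% and 10%. That estimate means an expected step of a number 0.5 percentage points higher from compound 2 to compound 3 (within the scatter), within the scatter.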

Compound 3, a percentage reported as inhibition, at one concentration (the size of the read-out at that concentration, not a potency): 1.15%
For compound 3 the middle estimate is 0.7 percentage points below the measured one, within the range that was stated.
By their numbers in this assay, from the lowest: compounds 2, 1 and 3 (each within the scatter of the next).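

In this assay, trifluoromethyl in place of ethoxy on an aromatic carbon gives a number 1.1 percentage points higher from compound 2 to compound 3 (within the scatter), and carboxy in place of hydroxy on an aromatic carbon gives a number 1.1 percentage points higher from compound 1 to compound 3 (within the scatter). Neither change therefore sets its pair apart at this concentration, so the trifluoromethyl-bearing core reads the same with carboxy or hydroxy, as the carboxy-bearing core does with ethoxy or trifluoromethyl. Nothing measured here bears on a cause. As far as these compounds go, whether an amine or a longer chain in place of ethoxy would give a step beyond the scatter stays open. So does whether an amide in place of carboxy would.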